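The source may hold more compounds than are shown below. What is called first, only, known or untested is meant among the compounds shown, and "the series" means these compounds.

Working notes on the series.

Compound 1 `COc1ccc(N2C[C@@H](C)N[C@@H](C)C2)cc1NS(=O)(=O)c1ccc(-c2ccccc2)cc1` gives 6.31 nM in a functional assay for agonist activity at growth hormone secretagogue receptor type 1 (Homo sapiens), read by FLIPR; a lower number here means that less compound is needed, a higher number that more compound is needed for the effect. Compound 2 `COc1ccc(N2C[C@@H](C)N[C@@H](C)C2)cc1NS(=O)(=O)c1ccc(-c2cccs2)cc1` gives 3.98 nM in this assay, and the step of a 1.6-fold lower number from compound 1 to compound 2 (0.20 log units; within the scatter) lies within the scatter. Compound 3 `COc1ccc(N2C[C@@H](C)N[C@@H](C)C2)cc1NS(=O)(=O)c1ccc(Oc2ccccc2)cc1` gives 63.1 nM in this assay, the highest of the three numbers: the steps of a 10-fold higher number from compound 1 to compound 3 (1.00 log units; beyond the scatter) and a 16-fold higher number from compound 2 to compound 3 (1.20 log units; beyond the scatter) both lie beyond the scatter, so compound 3 stands clearly apart from compound 1 and compound 2.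

Compound 4 `COc1ccc(N2C[C@@H](C)N[C@@H](C)C2)cc1NS(=O)(=O)c1ccc(OCc2ccccc2)cc1` is the next member, not yet measured in this assay. It differs from compound 3 in one place: benzyl in place of phenyl on an oxygen on an aromatic ring. Going by the values given here, no measured pair shows this change; the two steps into compound 3 show only that the move from a directly linked ring to an oxygen-linked ring raised the number, and offer no direct guide for the further extension to benzyloxy. The step from compound 3 to compound 4 is therefore expected to be small, a 1.6-fold higher number from compound 3 to compound 4 (0.20 log units; within the scatter), with a wide range in either direction. For compound 4 the estimate in this assay is 100 nM, with a range from 25 nM to 400 nM.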

Compound 4, half-maximal effective concentration: 100 nM
Beside the measured number, compound 4's estimate shows no gap at the digits printed; measured number inside the range.
By their numbers in this assay, from the lowest: compounds 2 and 1 (each within the scatter of the next); then compounds 3 and 4 (each within the scatter of the next).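

Benzyl in place of phenyl on an oxygen on an aromatic ring gives, in this assay, a 1.6-fold higher number from compound 3 to compound 4 (0.20 log units; within the scatter), so in this assay the phenoxy and benzyloxy compounds cannot be told apart. Benzyloxy in place of phenyl gives a 16-fold higher number from compound 1 to compound 4 (1.20 log units; beyond the scatter), and benzyloxy in place of thiophen-2-yl gives a 25-fold higher number from compound 2 to compound 4 (1.40 log units; beyond the scatter), so among these four compounds both oxygen-linked groups stand clearly apart from both directly linked rings, with no compound going against this. No measurement at hand accounts for these steps.

As far as these compounds go, whether a longer chain on the same oxygen, such as phenethyl, would stay within the scatter of compound 3 and compound 4 remains open. Also open, from the compounds shown here alone, is how an amine or a carboxylic acid on that chain would change the number.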